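This account rests on a few compounds, and the source may have more. Where it says the series, first, only, none or still open, it means among the compounds named here.

In an assay on isolated protein for inhibition of interferon-induced, double-stranded RNA-activated protein kinase (Homo sapiens), read by luminescence, with a stated time of 10 min (a lower number here means a stronger inhibitor, a higher number a weaker inhibitor), compound 1 `COCCCNc1nccc(-c2c(C)[nH]c3ccccc23)n1` gives 1500 nM. Two companions share its core and differ from it only in the group carried on the amine nitrogen. Compound 3 `Cc1[nH]c2ccccc2c1-c1ccnc(Nc2ccc(F)c(F)c2)n1` gives 1500 nM, and compound 2 `Cc1[nH]c2ccccc2c1-c1ccnc(NC(CO)C(C)C)n1` gives 50000 nM. The steps between these three are uneven: no change at the digits printed from compound 1 to compound 3 (within the scatter), while a 33-fold higher number from compound 1 to compound 2 (1.52 log units; beyond the scatter) and a 33-fold lower number from compound 2 to compound 3 (1.52 log units; beyond the scatter). Compound 1 therefore sits level with compound 3 at the low end of the three numbers, with compound 2 far off at the high end.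

Compound 4 `COCCCNc1nccc(-c2c(C)[nH]c3ccc(Cl)cc23)n1` leaves the amine substituent of compound 1 untouched and instead alters the fused ring system: chloro in place of hydrogen on an aromatic carbon. Among the measured compounds shown here, none of the measured steps touches that part of the molecule; all three swap the group on the nitrogen, so they give no direct guide to how large this change will be. For the measured compounds named here, with no measured step of the same kind to lean on, the expectation is a modest step, a 1.3-fold lower number from compound 1 to compound 4 (0.10 log units; within the scatter), one that may well stay inside the usual scatter of the assay. Compound 4 is accordingly estimated at 1200 nM, with a plausible range from 400 nM to 4000 nM.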

Compound 4, half-maximal inhibitory concentration: 3000 nM
Estimate against measurement, compound 4: 2.5-fold (0.40 log units) below, within the range that was stated.
By their numbers in this assay, from the lowest: compounds 1, 3 and 4 (each within the scatter of the next); then compound 2.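

Among the compounds shown here, this is the first look at the shared core away from the amine nitrogen. In this assay, chloro in place of hydrogen on an aromatic carbon of the six-membered aromatic ring of carbon only gives a 2.0-fold higher number from compound 1 to compound 4 (0.30 log units; within the scatter), so this single added chlorine atom leaves the two compounds indistinguishable, whereas a change on the nitrogen can matter far more, as in a 33-fold higher number from compound 1 to compound 2 (1.52 log units; beyond the scatter). No independent measurement is available to explain this result, so it stands as an observation only.

One substituent at one ring position, tested with one nitrogen group, cannot show how far this tolerance extends: fluoro, methoxy, nitrile or an amine on the same carbon might behave differently, and so might chloro on the other carbons of that ring. Going by these compounds, it also remains open whether chloro would give a similar result with the 3,4-difluorophenyl group of compound 3 on the nitrogen, or whether the effects of the two changes would fail to add up in a simple way.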